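Trading an amide for an ester on compound 1

The source may hold more compounds than are shown below. What is called first, only, known or untested is meant among the compounds shown, and "the series" means these compounds.

Compound 1 `CCOC(=O)c1sc2cc(Oc3ccnc(C(=O)NC)c3)ccc2c1C` carries ethoxy on one carbonyl carbon and methylamino on another. In an ADME assay on H1-HeLa cells (Homo sapiens) for cytotoxicity, read by MTT assay, with a stated time of 3 days (a lower number here means that less compound is tolerated, a higher number that more compound is tolerated), compound 1 gives 50900 nM. Its propoxy relative, compound 2 `CCCOC(=O)c1sc2cc(Oc3ccnc(C(=O)NC)c3)ccc2c1C`, gives 37400 nM, so these two sit together: a 1.4-fold lower number from compound 1 to compound 2 (0.13 log units; within the scatter). Compound 3 `CCNC(=O)c1sc2cc(Oc3ccnc(C(=O)NC)c3)ccc2c1C`, with ethylamino in place of the ester's alkoxy group, reads > 100000 nM, which is a limit of the assay and not a number.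

Compound 4 `CCOC(=O)c1sc2cc(Oc3ccnc(C(=O)OC)c3)ccc2c1C` keeps the ethoxy group of compound 1 and alters the other carbonyl: methoxy in place of methylamino on a carbonyl carbon. In words, methoxy takes the place of methylamino on a carbonyl carbon. The nearest measured changes run the opposite way, from ester to amide, and at a different carbonyl: an at least 1.9-fold higher number from compound 1 to compound 3 (0.29 log units; that floor lies within the scatter), and an at least 2.6-fold higher number from compound 2 to compound 3 (0.42 log units; beyond the scatter). Read in reverse, they suggest a modest move towards a lower number, though this is only a loose guide. The expected change is a 1.8-fold lower number from compound 1 to compound 4 (0.26 log units; within the scatter). Compound 4 is estimated at 28000 nM, with an expected range from 9000 nM to 80000 nM.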

Compound 4, half-maximal cytotoxic concentration: 24900 nM
Estimate against measurement, compound 4: 1.1-fold (0.05 log units) above; low and high end bracket the measured number.
By their numbers in this assay, from the lowest: compounds 4, 2 and 1 (each within the scatter of the next, the first and the last beyond it). At a limit, above all of these: compound 3.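

Among these compounds, compound 4 is the first compound here to vary the second carbonyl, and it shows that this place also moves the number in this assay: methoxy in place of methylamino gives a 2.0-fold lower number from compound 1 to compound 4 (0.31 log units; beyond the scatter). At the other carbonyl, the amide also stands with the higher number, with an at least 2.6-fold higher number from compound 2 to compound 3 (0.42 log units; beyond the scatter), although an at least 1.9-fold higher number from compound 1 to compound 3 (0.29 log units; that floor lies within the scatter) only has a floor within the scatter. How the two amide changes compare in size stays unknown, since compound 3 reads only a limit: the limit of > 100000 nM in this assay, at which 1 of the 4 values shown sits.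

Still open, going by these compounds, is how this carbonyl carbon behaves with a carboxylic acid, a plain primary amide or a longer chain on the amide nitrogen. Also open, on these data alone, is whether methoxy here would lower the number when ethylamino sits on the other carbonyl.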